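Swapping a Fluorine for a Phenyl on the Shared Core

The compounds below may be only part of what the source reports. "The series", "measured", "known", "first", "only" and "open" are said of these compounds alone.

Compound 1 `COc1cc(-n2c(-c3ccc(F)cc3)csc2=S)cc(OC)c1OC` and compound 2 `COc1cc(-n2c(-c3ccc(Cl)cc3Cl)csc2=S)cc(OC)c1OC` share one core and differ only in the aryl group attached to it. In a functional assay on MCF7 cells (Homo sapiens) for cytotoxicity, read by MTT assay, with a stated time of 48 h (a lower number here means a stronger inhibitor, a higher number a weaker inhibitor), compound 1 gives 38.5 ug/mL and compound 2 gives 23.6 ug/mL. Among the two numbers shown, compound 1 has the highest, yet the only step between them, a 1.6-fold lower number from compound 1 to compound 2 (0.21 log units; within the scatter), lies within the scatter, so the two aryl groups cannot be told apart here.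

Compound 3 `COc1cc(-n2c(-c3ccc(-c4ccccc4)cc3)csc2=S)cc(OC)c1OC` has not been measured. It differs from compound 1 by phenyl in place of fluoro on an aromatic carbon, a change on an aromatic carbon of the same ring. Among the measured compounds shown here, the one measured step that bears on a change at this ring is a 1.6-fold lower number from compound 1 to compound 2 (0.21 log units; within the scatter), and it stayed within the scatter. On that basis no step beyond the scatter is expected in this assay, in either direction. Compound 3 is therefore estimated at 35 ug/mL, with a range from 12 ug/mL to 100 ug/mL, an expected step of a 1.1-fold lower number from compound 1 to compound 3 (0.04 log units; within the scatter).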

Compound 3, half-maximal inhibitory concentration: 45.3 ug/mL
Compound 3: middle estimate off by 1.3-fold (0.11 log units), on the low side; measured number inside the range.
By their numbers in this assay, from the lowest: compounds 2, 1 and 3 (each within the scatter of the next).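

Phenyl brings six heavy atoms and a whole second aromatic ring where fluoro had a single atom, yet this assay records only a 1.2-fold higher number from compound 1 to compound 3 (0.07 log units; within the scatter). This shows that a much larger group can sit on this aromatic carbon without a step beyond the scatter, something the earlier comparison of compound 1 and compound 2, which swapped halogen patterns only, could not show. No measurement shown offers an explanation for this result.

Fluoro and phenyl both count no hydrogen-bond donors or acceptors and no net charge, so it remains open whether an amine or a carboxylic acid at this position would give a step beyond the scatter. Going by these compounds, a longer carbon chain in the same place is equally open, as is whether any of these results would hold on other cells.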